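Cytotoxicity on the shared core: a cyclopentylamino analog

This account rests on a few compounds, and the source may have more. Where it says the series, first, only, none or still open, it means among the compounds named here.

Three compounds share one core and differ only at a single aromatic carbon. Compound 1 `CC(C)CSc1nc(N)nc2c1ncn2/C=C1/CC1(CO)CO` carries isobutylsulfanyl there. In an ADME assay on HFF cells (Homo sapiens) for cytotoxicity, with a stated time of 8 days (a lower number here means that less compound is tolerated, a higher number that more compound is tolerated), compound 1 gives > 300000 nM, which is a limit of the assay and not a number. Compound 2 `CCCSc1nc(N)nc2c1ncn2/C=C1/CC1(CO)CO` carries propylsulfanyl; in this assay compound 2 gives > 300000 nM, again a limit. Compound 3 `Nc1nc(NCc2ccccc2)c2ncn(/C=C3/CC3(CO)CO)c2n1` carries benzylamino; in this assay compound 3 gives > 300000 nM, also a limit. The three steps are therefore unreadable in size: a step that the two limits leave unreadable from compound 1 to compound 2, a step that the two limits leave unreadable from compound 1 to compound 3 and a step that the two limits leave unreadable from compound 2 to compound 3. The one thing the data show is the limit of > 300000 nM in this assay, at which 3 of the 3 values shown sit.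

Compound 4 `Nc1nc(NC2CCCC2)c2ncn(/C=C3/CC3(CO)CO)c2n1` differs from compound 1 by cyclopentylamino in place of isobutylsulfanyl on an aromatic carbon. The steps from compound 1 to compound 3 and from compound 2 to compound 3, where benzylamino replaced a sulfanyl group, are the nearest to this change; both sat at the limit on either side, so no size and no direction can be read from them. Nothing in the series points to a cytotoxic concentration that would come inside the measured range, and compound 4 is expected to remain at the limit, with the expected step that the limit leaves unreadable from compound 1 to compound 4 not readable beyond the scatter. Compound 4 is estimated at 350000 nM, with a range from 150000 nM to 1000000 nM.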

Compound 4, half-maximal cytotoxic concentration: > 300000 nM
Compound 4 was reported as a limit; the forecaster's own chance of this, stated with the estimate: 80%; the middle value lies beyond the limit too.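

In this assay compound 4 gives > 300000 nM, a limit of the assay and not a number. Within the data shown here, no step linking compound 4 with compound 1, compound 2 or compound 3 can be read, in size or in direction. The compounds shown leave open at what concentration any of the four becomes cytotoxic, and whether the group on the aromatic carbon alters that concentration.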